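The source may report more compounds than this note shows. Statements on the series, on what has been measured and on what is new or still open speak of the compounds shown alone.

Working notes on the series. Compound 1 is `Cc1cc(I)cn2c(CSCCc3ccccc3)cnc12`, compound 2 is `Cc1cc(-c2cccc(C#N)c2)cn2c(CSCCc3ccccc3)cnc12` and compound 3 is `Cc1cc(Br)cn2c(CSCCc3ccccc3)cnc12`; all share one core. In an ADME assay on HEL cells (Homo sapiens) for cytotoxicity, with a stated time of 3 days (on this read-out lower numbers stand for higher toxicity in this test and higher numbers for lower toxicity in this test), compound 1 gives >= 0.8 ug/mL, a limit of the test rather than a number. Compound 2 gives > 100 ug/mL in this assay, again a limit. Compound 3 gives >= 2 ug/mL in this assay, also a limit. With every reading a limit, the steps a step that the two limits leave unreadable from compound 1 to compound 2, a step that the two limits leave unreadable from compound 1 to compound 3 and a step that the two limits leave unreadable from compound 2 to compound 3 cannot be sized; compound 3 stands with a limit of its own beside two further limits, the limit of >= 2 ug/mL in this assay, at which 1 of the 3 values shown sits, next to the limit of > 100 ug/mL in this assay, at which 1 of the 3 values shown sits, and (the limit of >= 0.8 ug/mL in this assay, at which 1 of the 3 values shown sits).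

Compound 4 is `Cc1cc(-c2ccccc2O)cn2c(CSCCc3ccccc3)cnc12`. The change from compound 3 is 2-hydroxyphenyl in place of bromo on an aromatic carbon. The measured steps that bear on it are the aryl-for-halogen steps a step that the two limits leave unreadable from compound 1 to compound 2 and a step that the two limits leave unreadable from compound 2 to compound 3, neither of them readable in size. Among the compounds with values here, the only aryl-bearing analogue, compound 2, sat at the limit of > 100 ug/mL in this assay, at which 1 of the 3 values shown sits, which points toward lower toxicity for an aryl group at this carbon, though one compound is thin ground. The step that the limit leaves unreadable from compound 3 to compound 4 is therefore expected to run toward lower toxicity, its size uncertain. Compound 4 is expected to give about 60 ug/mL in this assay, with a range from 15 ug/mL to 200 ug/mL.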

Compound 4, minimum cytotoxic concentration: 100 ug/mL
For compound 4 the middle estimate is 1.7-fold (0.22 log units) below the measured one, and the stated range covers the measured number.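

In this assay, within the data shown here, compound 4 gives 100 ug/mL, the first reading for a group at this aromatic carbon that is a number and not a limit, which gives the series a fixed point that compound 1, compound 2 and compound 3 did not provide. Between the two aryl groups the reading is a number no higher from compound 2 to compound 4 (the limit leaves the size open), while the steps from bromo and from iodo cannot be read, so no change at this carbon can yet be given a size. The reading of compound 3 remains a limit, and no direction follows for the change from bromo: the limit of >= 2 ug/mL in this assay, at which 1 of the 4 values shown sits.

The compounds shown leave open whether the reading of compound 4 belongs to the aryl ring itself or to its hydroxyl, a question that an unsubstituted phenyl or a 2-aminophenyl group at this carbon would address. Also open, going by these compounds, is how a group without an aromatic ring would read here, such as a morpholine or a longer alkyl chain.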